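Swapping a dichlorophenyl for chlorofluorophenyl on a sulfonyl group

This account rests on a few compounds, and the source may have more. Where it says the series, first, only, none or still open, it means among the compounds named here.

Of the compounds shown here, three have been measured in an ADME assay on microsomes from liver (Homo sapiens) for metabolic stability, tested at 2.5 uM; a lower number here means slower removal, a higher number faster removal of the compound. Compound 1 `O=S(=O)(c1cc(Cl)cc(Cl)c1)c1cnc2cc(F)ccc2c1-c1ccccc1F` gives 0.93 mL/min. Compound 2 `O=S(=O)(c1ccc(F)c(Cl)c1)c1cnc2cc(F)ccc2c1-c1ccccc1F` gives 1.07 mL/min. Compound 3 `COc1ccc(-c2c(S(=O)(=O)c3cc(Cl)cc(Cl)c3)cnc3cc(F)ccc23)cc1` gives 1 mL/min. The change from compound 1 to compound 2 is 3-chloro-4-fluorophenyl in place of 3,5-dichlorophenyl on a sulfonyl sulfur, and it made a step of a 1.2-fold higher number from compound 1 to compound 2 (0.06 log units; within the scatter). The cores of compound 1 and compound 3 differ by 4-methoxyphenyl in place of 2-fluorophenyl on an aromatic carbon, a step of a 1.1-fold higher number from compound 1 to compound 3 (0.03 log units; within the scatter).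

Compound 4 `COc1ccc(-c2c(S(=O)(=O)c3ccc(F)c(Cl)c3)cnc3cc(F)ccc23)cc1` has not been measured. It differs from compound 3 by 3-chloro-4-fluorophenyl in place of 3,5-dichlorophenyl on a sulfonyl sulfur, the same change as from compound 1 to compound 2, at the same kind of place. For this reason the step from compound 3 to compound 4 in this assay is expected to be a 1.2-fold higher number from compound 3 to compound 4 (0.06 log units; within the scatter), resting on a 1.2-fold higher number from compound 1 to compound 2 (0.06 log units; within the scatter). Compound 4 is therefore estimated at 1.15 mL/min, likely between 0.6 mL/min and 2.2 mL/min.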

Compound 4, intrinsic clearance in a liver preparation (reported as CLH), per the amount of preparation that the assay uses: 1.08 mL/min
Estimate against measurement, compound 4: 1.1-fold (0.03 log units) above, and the stated range covers the measured number.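

The sulfonyl swap looks the same on both cores, with a 1.1-fold higher number from compound 3 to compound 4 (0.03 log units; within the scatter) in this assay: the same change on two cores in this assay, a 1.2-fold higher number (0.06 log units; within the scatter) from compound 1 to compound 2 and a 1.1-fold higher number (0.03 log units; within the scatter) from compound 3 to compound 4, 1.1-fold (0.03 log units) apart, within the scatter of two such steps

The swap to 4-methoxyphenyl in place of 2-fluorophenyl also looks the same on both cores, with a 1.0-fold higher number from compound 2 to compound 4 (0.00 log units; within the scatter): the same change on two cores in this assay, a 1.1-fold higher number (0.03 log units; within the scatter) from compound 1 to compound 3 and a 1.0-fold higher number (0.00 log units; within the scatter) from compound 2 to compound 4, 1.1-fold (0.03 log units) apart, within the scatter of two such steps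

All of these steps lie within the scatter, so the four compounds show that neither change visibly shifts the number on these cores, not that a step of real size would carry over equally.

The compounds shown leave open how removal would respond to a quite different group on the sulfonyl sulfur, such as an amine. They also leave open what a carboxylic acid on the aromatic carbon that holds the 4-methoxyphenyl would do.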